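From diethylamino to pyrrolidin-1-yl on a shared core

A few compounds are considered here, and "the series" means these few. Any claim that something is new, unique, unknown or untested is made for them only; others in the source may bear on it.

Compound 1 `O=C(CC(CC(=O)NC1Cc2ccccc2C1)c1ccc(Cl)cc1)NCCN1CCCCC1`: 70400 nM
Compound 2 `CCN(CC)CCNC(=O)CC(CC(=O)NC1Cc2ccccc2C1)c1ccc(Cl)cc1`: 76700 nM

Within the data shown here, in a functional assay on L02 cells (Homo sapiens) for inhibition (a lower number here means a stronger inhibitor, a higher number a weaker inhibitor), compound 2 gives 76700 nM, which cannot be told apart from the only other measured value. Compound 3 `O=C(CC(CC(=O)NC1Cc2ccccc2C1)c1ccc(Cl)cc1)NCCN1CCCC1` keeps the shared core and changes one group: pyrrolidin-1-yl in place of diethylamino on a saturated chain carbon, two bonds along the chain from an amide-type nitrogen. In words, pyrrolidin-1-yl takes the place of diethylamino on a saturated chain carbon, two bonds along the chain from an amide-type nitrogen. Among the measured compounds shown here, compound 1 carries piperidin-1-yl at that same place, so the one measured step bears directly on this change. Swapping piperidin-1-yl for diethylamino gave a 1.1-fold higher number from compound 1 to compound 2 (0.04 log units; within the scatter). A single step is thin evidence, but it points to no change beyond the scatter in this assay, in either direction. The expected change is a 1.1-fold lower number from compound 2 to compound 3 (0.03 log units; within the scatter). For compound 3 the estimate is 72000 nM, with an expected range of 40000 nM to 130000 nM.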

Compound 3, half-maximal inhibitory concentration: 89400 nM
Estimate against measurement, compound 3: 1.2-fold (0.09 log units) below; low and high end bracket the measured number.
By their numbers in this assay, from the lowest: compounds 1, 2 and 3 (each within the scatter of the next).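

In this assay, closing the two ethyl arms of diethylamino into pyrrolidin-1-yl gives a 1.2-fold higher number from compound 2 to compound 3 (0.07 log units; within the scatter), and shrinking the ring from piperidin-1-yl to pyrrolidin-1-yl gives a 1.3-fold higher number from compound 1 to compound 3 (0.10 log units; within the scatter). With both steps within the scatter, all three groups at this place now read alike, whether the end of the chain is open or a ring, and whether that ring has five or six members. No measurement here offers an explanation for this flat result.

These three groups have similar sizes and each holds a single nitrogen, so the flatness may not extend to very different ends. A morpholin-4-yl ring, a plain primary amine, a carboxylic acid or a longer chain in the same place could still shift the number.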